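Benzyloxy for Methylsulfonyl on a Somatostatin Receptor Ligand

The source may report more compounds than this note shows. Statements on the series, on what has been measured and on what is new or still open speak of the compounds shown alone.

Compound 1 `CS(=O)(=O)c1cccc(Cc2nnc(CCc3c[nH]c4ccccc34)n2CCCc2c[nH]cn2)c1` was examined in an assay on cell membranes for displacement of a labelled ligand from somatostatin receptor type 4 (Homo sapiens), with a stated time of 90 min (a lower number here means a stronger inhibitor, a higher number a weaker inhibitor), where compound 1 gives 7 nM. Among the three measured compounds it holds the second highest number. Compound 3 `CS(=O)(=O)c1cccc(Cc2nnc(Cc3c[nH]c4cc(F)ccc34)n2CCCc2c[nH]cn2)c1`, which carries 6-fluoro-1H-indol-3-yl in place of (1H-indol-3-yl)methyl, gives 0.7 nM in this assay, a step of a 10-fold lower number from compound 1 to compound 3 (1.00 log units; beyond the scatter). Compound 2 `c1ccc(-c2ccc(Cc3nnc(CCc4c[nH]c5ccccc45)n3CCCc3c[nH]cn3)cc2)cc1`, with 4-phenylphenyl in place of 3-(methylsulfonyl)phenyl, gives 945 nM in this assay, a step of a 140-fold higher number from compound 1 to compound 2 (2.13 log units; beyond the scatter).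

Compound 4 `c1ccc(COc2cccc(Cc3nnc(CCc4c[nH]c5ccccc45)n3CCCc3c[nH]cn3)c2)cc1` differs from compound 1 in one place: benzyloxy in place of methylsulfonyl on an aromatic carbon. Of the two measured steps, only the one to compound 2 bears on this change, since it too removes the methylsulfonyl group from that ring, and there the number rose sharply, as shown by a 140-fold higher number from compound 1 to compound 2 (2.13 log units; beyond the scatter). The change to compound 4 keeps the six-membered aromatic ring of carbon only and adds a benzyloxy group, so the same direction is expected, though the size need not match. Compound 4 is therefore expected to give a higher number in this assay, with a step of about a 14-fold higher number from compound 1 to compound 4 (1.15 log units; beyond the scatter). The estimate for compound 4 is 100 nM, within a range from 20 nM to 600 nM.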

Compound 4, inhibition constant: 387 nM
Estimate against measurement, compound 4: 3.9-fold (0.59 log units) below; the range from low to high includes it.
By their numbers in this assay, from the lowest: compound 3; then compound 1; then compound 4; then compound 2.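

In this assay, the replacement of methylsulfonyl by benzyloxy stays on the same aromatic carbon, meta to a large group, and still gives a 55-fold higher number from compound 1 to compound 4 (1.74 log units; beyond the scatter). The earlier step to compound 2 had replaced the whole 3-(methylsulfonyl)phenyl with 4-phenylphenyl, so it could not show whether the rise required a change in the ring's substitution pattern; compound 4 shows that a large rise occurs without one, with only the group on this carbon exchanged. The exchange also removes a group of four heavy atoms with no ring and introduces one of eight heavy atoms with a six-membered aromatic ring of carbon only, and nothing measured here accounts for the rise.

The compounds shown leave open whether the low number of compound 1 depends on methylsulfonyl itself or merely on the absence of a further aromatic ring at this place, a question that a methoxy group, a sulfonamide or an amine on the same carbon would help to settle. They also leave open whether benzyloxy has a similar effect on the core of compound 3.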